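The compounds below may be only part of what the source reports. "The series", "measured", "known", "first", "only" and "open" are said of these compounds alone.

In an ADME assay on L02 cells (Homo sapiens) for cytotoxicity, read by MTT assay, with a stated time of 24 h (on this read-out higher numbers stand for weaker inhibition and lower numbers for stronger inhibition), compound 1 `COc1ccc(/C=C2\CN(C)C/C(=C\c3ccncc3)C2=O)c(OC)c1OC` gives 15600 nM and compound 2 `CN1C/C(=C\c2ccncc2)C(=O)/C(=C/c2ccccc2C(F)(F)F)C1` gives 15800 nM on the same read-out. Compound 3 `O=C1/C(=C/c2cccnc2)CN(S(=O)(=O)c2ccccc2)C/C1=C\c1ccccc1F` at 15300 nM stands within the scatter of both, so the three cannot be ordered. Compound 4 `O=C1/C(=C/c2cccnc2)CN(S(=O)(=O)c2ccc(Cl)cc2)C/C1=C\c1ccccc1F` differs from compound 3 in one place (chloro in place of hydrogen on an aromatic carbon) with chloro in place of hydrogen on an aromatic carbon, taking phenylsulfonyl to (4-chlorophenyl)sulfonyl. Among the measured compounds shown here, no measured pair differs in one place, so nothing sizes this change directly. The expected 1.2-fold lower number from compound 3 to compound 4 (0.07 log units; within the scatter) is small and points slightly toward stronger inhibition, with no step beyond the scatter expected. In this assay compound 4 is estimated at 13000 nM with an expected range from 7000 nM to 24000 nM for repeat measurements.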

Compound 4, half-maximal inhibitory concentration: > 20000 nM
Compound 4: only a limit was reported; the forecaster's own chance of this, stated with the estimate: 5%; middle value at least 1.5-fold (0.18 log units) from the limit.
By their numbers in this assay, from the lowest: compounds 3, 1 and 2 (each within the scatter of the next). At a limit, above all of these: compound 4.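

Compound 4 is reported only as a limit of the assay, not as a number: the limit of > 20000 nM in this assay, at which 1 of the 4 values shown sits. In this assay, the series now has a pair differing in one place, giving an at least 1.3-fold higher number from compound 3 to compound 4 (0.11 log units; that floor lies within the scatter) for chloro in place of hydrogen on an aromatic carbon, para to a large group. This floor does not establish a change, but the pair gives no sign of stronger inhibition with chloro at this position.

From the compounds shown here alone, the true size of the step remains open. So does whether a methoxy group or an amine at this position would read as chloro does.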